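Adding ethyl to compound 2

The source may hold more compounds than are shown below. What is called first, only, known or untested is meant among the compounds shown, and "the series" means these compounds.

Measured in a functional assay on HeLa cells (Homo sapiens) for antiproliferative activity, read by sulforhodamine B assay (a higher number here means a weaker inhibitor of growth, a lower number a stronger inhibitor of growth), so far:
Compound 1 `c1ccc(COC[C@H]2OCC[C@@H](OCc3ccccc3)[C@@H]2OCc2ccccc2)cc1` – 33300 nM
Compound 2 `O[C@H]1CO[C@H](COCc2ccccc2)[C@@H](OCc2ccccc2)[C@@H]1OCc1ccccc1` – > 50000 nM
Compound 3 `CC(=O)O[C@@H]1[C@@H](OCc2ccccc2)[C@H](OCc2ccccc2)[C@@H](COCc2ccccc2)O[C@H]1C` – > 50000 nM

Compound 2 gives > 50000 nM, which is a limit of the assay and not a number. Compound 3 gives > 50000 nM, also a limit. Both sit at the limit of > 50000 nM in this assay, at which 2 of the 3 values shown sit.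

Compound 4 `CC[C@@H]1O[C@H](COCc2ccccc2)[C@@H](OCc2ccccc2)[C@H](OCc2ccccc2)[C@H]1O` differs from compound 2 by one change, ethyl in place of hydrogen on a saturated ring carbon, next to the ring oxygen. For the measured compounds named here, the only measured step, an at least 1.5-fold higher number from compound 1 to compound 2 (0.17 log units; that floor lies within the scatter), concerns a hydroxy group rather than ethyl. It stays within the scatter, so no clear step is expected in this assay. The expected change is an at least 1.1-fold lower number from compound 2 to compound 4 (0.04 log units; that floor lies within the scatter). Compound 4 is estimated at 45000 nM (from 20000 nM to 80000 nM) .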

Compound 4, concentration for 50% growth inhibition: 19800 nM
Compound 4: the middle estimate sits 2.3-fold (0.36 log units) above what was measured; the measured number lies below the stated range.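

In this assay, ethyl in place of hydrogen on this saturated ring carbon, next to the ring oxygen, gives an at least 2.5-fold lower number from compound 2 to compound 4 (0.40 log units; beyond the scatter). This is the first step shown that lies beyond the scatter, so this position can respond to a small carbon group. The step starts from a limit of the assay and not a number, so its true size stays unknown: the limit of > 50000 nM in this assay, at which 2 of the 4 values shown sit.

On these data alone, whether a longer chain such as propyl, or an amine, at this position would give a lower number still remains open. So does whether ethyl would give a similar step on the core of compound 1.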